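Lengthening the carbonyl chain from compound 3 to compound 4

The compounds below may be only part of what the source reports. "The series", "measured", "known", "first", "only" and "open" are said of these compounds alone.

Measured so far in a functional assay on MCF7 cells (Homo sapiens) for inhibition, with a stated time of 48 h, tested at 50 uM; a lower number here means less inhibition of growth, a higher number more inhibition of growth at the concentration tested:
Compound 1 `C=C[C@@](C)(/C=C/c1ccc(OC(=O)CCC)cc1)CCC=C(C)C` gives 20%
Compound 2 `C=C[C@@](C)(/C=C/c1ccc(OC(=O)CCCC)cc1)CCC=C(C)C` gives 25%
Compound 3 `C=C[C@@](C)(/C=C/c1ccc(OC(=O)CCCCC)cc1)CCC=C(C)C` gives 18%

Compound 3 at 18% sits within the scatter of both compound 1 and compound 2, and the three values show no order with chain length. Compound 4 (`C=C[C@@](C)(/C=C/c1ccc(OC(=O)CCCCCCC)cc1)CCC=C(C)C`) is still unmeasured. Its change from compound 3 is ethyl in place of hydrogen on a saturated chain carbon, five bonds along the chain from a carbonyl carbon and reads in words as ethyl in place of hydrogen on a saturated chain carbon, five bonds along the chain from a carbonyl carbon.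

Among the measured compounds shown here, three measured steps bear on this. The closest in kind is ethyl in place of hydrogen on a saturated chain carbon, three bonds along the chain from a carbonyl carbon, which gave a number 2 percentage points lower from compound 1 to compound 3 (within the scatter) and sets the scale. Methyl in place of hydrogen gave a number 5 percentage points higher from compound 1 to compound 2 (within the scatter) at three bonds along the chain and a number 7 percentage points lower from compound 2 to compound 3 (within the scatter) at four bonds along the chain. For the measured compounds named here, no measured pair covers the change at five bonds along the chain. In this assay no step beyond the scatter is therefore expected, in either direction. The expected step is a number 1 percentage points higher from compound 3 to compound 4 (within the scatter) on this reading. Compound 4 is estimated at 19% with an expected range from 7% to 32% for its measurement.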

Compound 4, percent growth inhibition at one concentration: 12%
Compound 4: middle estimate off by 7 percentage points, on the high side; the range from low to high includes it.
By their numbers in this assay, from the lowest: compounds 4, 3, 1 and 2 (each within the scatter of the next, the first and the last beyond it).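

In this assay, ethyl in place of hydrogen on a saturated chain carbon, five bonds along the chain from a carbonyl carbon, gives a number 6 percentage points lower from compound 3 to compound 4 (within the scatter), so this change alone does not leave the scatter. Among the compounds shown here, the longer chain does yield the first step beyond the scatter, a number 13 percentage points lower from compound 2 to compound 4 (beyond the scatter), but this modest separation is not general, as the longer span gives a number 8 percentage points lower from compound 1 to compound 4 (within the scatter) and stays within the scatter. This does not establish a steady trend with chain length, since compound 1 and compound 3 fit no such order, and no measurement on hand offers an explanation for the separation.

Going by these compounds, whether a longer chain in place of the ethyl would extend the separation from compound 2 or leave the number within the scatter of compound 4 remains open. Also open is how an amine or a carboxylic acid in place of the ethyl would read in this assay, as the compounds shown carry only saturated chains at this place.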